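The compounds below may be only part of what the source reports. "The series", "measured", "known", "first", "only" and "open" are said of these compounds alone.

Measured compounds:
compound 1 `Nc1scc(CN2CCN(c3ccc(F)cc3Cl)CC2)c1C(=O)c1ccc(Cl)cc1` — 6.1%
compound 2 `COc1ccc(N2CCN(Cc3csc(N)c3C(=O)c3ccc(Cl)cc3)CC2)cc1` — -1.2%
compound 3 `Nc1scc(CN2CCN(c3ccc(Cl)c(C(F)(F)F)c3)CC2)c1C(=O)c1ccc(Cl)cc1` — -2.5%

All three were tested in a functional assay on CHO cells with adenosine receptor A1 (Homo sapiens) as the target, read by cAMP accumulation and immunoassay, with a stated time of 6 min, tested at 0.01 uM; on this read-out lower numbers stand for a stronger effect and higher numbers for a weaker effect at the one concentration tested. Compound 3 stands at the low end of the three numbers, but only nominally: from compound 2 the step is a number 1.3 percentage points lower from compound 2 to compound 3 (within the scatter), and from compound 1 it is a number 8.6 percentage points lower from compound 1 to compound 3 (within the scatter). The remaining step, a number 7.3 percentage points lower from compound 1 to compound 2 (within the scatter), is likewise within the scatter, so the three numbers form one flat band regardless of the aryl group carried on the amine nitrogen in the ring.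

Compound 4 `Nc1scc(CN2CCN(C3CCCCCC3)CC2)c1C(=O)c1ccc(Cl)cc1` is not yet measured. Relative to compound 3 the change is cycloheptyl in place of 4-chloro-3-(trifluoromethyl)phenyl on an amine nitrogen in a ring. Going by the values given here, no measured step bears on this directly: every step seen so far exchanges one aryl group for another, and none replaces an aryl group with a saturated carbocycle. What the series does show is that three quite different groups at this position leave this assay unmoved. On that basis no step beyond the scatter is expected; the estimated step is a number 2.5 percentage points higher from compound 3 to compound 4 (within the scatter). Compound 4 is therefore expected to give about 0%, with a range of -10% to 12%.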

Compound 4, a percentage reported as activity, at one concentration (the size of the read-out at that concentration, not a potency): 2.9%
Beside the measured number, compound 4's estimate is 2.9 percentage points below it; low and high end bracket the measured number.
By their numbers in this assay, from the lowest: compounds 3, 2, 4 and 1 (each within the scatter of the next).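

In this assay, cycloheptyl on the amine nitrogen in the ring falls in the same flat band as the aryl groups, whichever of them it replaces (a number 5.4 percentage points higher from compound 3 to compound 4 (within the scatter); a number 4.1 percentage points higher from compound 2 to compound 4 (within the scatter); a number 3.2 percentage points lower from compound 1 to compound 4 (within the scatter)). The band therefore extends beyond aryl exchanges: among the compounds shown, a six-membered aromatic ring of carbon only on this nitrogen is not required for a number in this range, and a seven-membered non-aromatic ring of carbon only serves as well. No evidence is available to account for this flatness.

Open, from the compounds shown here alone, is whether a methyl, an aminoethyl chain or a carboxylic acid-bearing chain on the same nitrogen would stay within this band. A single concentration also leaves open whether a full concentration series would separate these compounds.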